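Compound 3 to compound 4: bromomethyl for bromo

The source may report more compounds than this note shows. Statements on the series, on what has been measured and on what is new or still open speak of the compounds shown alone.

Within the data shown here, in a functional assay on KB cells (Homo sapiens) for antiproliferative activity, read by sulforhodamine B assay, with a stated time of 3 days (a lower number here means that less compound is needed, a higher number that more compound is needed for the effect), compound 1 (`CCC1=C(O)c2c(oc(-c3ccc(C(C)C)cc3)cc2=O)C(CC)(CC)C1=O`) gives 8.13 uM and is the only compound of the three with a true number. Compound 2 (`CCCOc1ccc(-c2cc(=O)c3c(o2)C(CC)(CC)C(=O)C(CC)=C3O)cc1`) has only the limit > 50.5 uM as its result. Compound 3 (`CCC1=C(O)c2c(oc(-c3ccc(Br)cc3)cc2=O)C(CC)(CC)C1=O`) also has only a limit, > 48.1 uM as reported, and so its position is open on the upper side. Among the measured compounds shown here, the data show a step that the two limits leave unreadable from compound 2 to compound 3 and give no order for that pair.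

Compound 4 (`CCC1=C(O)c2c(oc(-c3ccc(CBr)cc3)cc2=O)C(CC)(CC)C1=O`) carries bromomethyl in place of bromo on an aromatic carbon and keeps the rest of compound 3 unchanged. For the measured compounds named here, no measured step covers this exact change. The nearest evidence is the pair of steps away from isopropyl: propoxy gives an at least 6.2-fold higher number from compound 1 to compound 2 (0.79 log units; beyond the scatter) and bromo gives an at least 5.9-fold higher number from compound 1 to compound 3 (0.77 log units; beyond the scatter) on the same aromatic carbon.

Both steps are lower limits on size. Compound 1 at 8.13 uM marks the only measured level for this position, so a move in this assay toward that level is expected. A second limit remains possible. The expected size is an at least 3.4-fold lower number from compound 3 to compound 4 (0.53 log units; beyond the scatter) with low confidence. For compound 4 the estimate is 14 uM with an expected range of 3.5 uM to 50 uM in this series.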

Compound 4, concentration for half-maximal effect: > 46.5 uM
Compound 4: no number, only a limit (the forecaster's own chance of this, stated with the estimate: 30%); at least 3.3-fold (0.52 log units) between middle value and limit.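

In this assay compound 4 also returns only a limit, > 46.5 uM, and not a number. Among these compounds, measured against the isopropyl compound, the change gives an at least 5.7-fold higher number from compound 1 to compound 4 (0.75 log units; beyond the scatter), so bromomethyl now stands with propoxy and bromo as a replacement on this aromatic carbon that moves the read-out away from the level of compound 1, which remains the only compound here with a true number. The change from bromo to bromomethyl has no readable size, and the same holds for the other steps among compound 2, compound 3 and compound 4, each of which joins two limits.

As far as these compounds go, the true values of compound 2, compound 3 and compound 4 stay unknown, and so does any order among them. From the compounds shown here alone, it also stays open whether a true number at this position needs a branched carbon group like isopropyl, a question that tert-butyl or a longer chain on the same carbon could test, while an amine or a carboxylic acid there would show how far the read-out follows groups of a different kind.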